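The source may hold more compounds than are shown below. What is called first, only, known or untested is meant among the compounds shown, and "the series" means these compounds.

Values in a functional assay on A549 cells (Homo sapiens) for antiproliferative activity, read by MTT assay, with a stated time of 48 h; on this read-out lower numbers stand for stronger inhibition and higher numbers for weaker inhibition

compound 1 `Cc1ccc(Nc2ccc3c(c2)C(CCC(C)C)C(=O)N3)cc1` gives 6600 nM
compound 2 `Cc1ccc(Nc2ccc3c(c2)C(CC2CCCCC2)C(=O)N3)cc1` gives > 30000 nM (a limit of the assay, not a number)
compound 3 `CC(C)CCC1C(=O)Nc2ccc(Nc3ccc(Cl)cc3)cc21` gives 2000 nM
compound 4 `O=C1Nc2ccc(Nc3ccc(Cl)cc3)cc2C1CC1CCCCC1` is not yet measured

Compound 3 holds the lower of the two actual numbers in this assay, and the nearest is compound 1 at 6600 nM. That gap is a 3.3-fold lower number from compound 1 to compound 3 (0.52 log units; beyond the scatter), a change of chloro in place of methyl on an aromatic carbon.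

The next change is cyclohexyl in place of isobutyl on a saturated chain carbon bound to a saturated ring carbon, in words cyclohexyl in place of isobutyl on a saturated chain carbon bound to a saturated ring carbon. The same exchange has been measured once, in the methyl-bearing pair, as an at least 4.5-fold higher number from compound 1 to compound 2 (0.65 log units; beyond the scatter). That step has only a lower bound because the limit of > 30000 nM in this assay, at which 1 of the 3 values shown sits, applies to compound 2 . Among the measured compounds shown here, whether it carries over to the chloro-bearing pair is untested, since this single pair is the only precedent.

A step of at least similar size towards a higher number, beyond the scatter, is therefore expected in this assay, resting on an at least 4.5-fold higher number from compound 1 to compound 2 (0.65 log units; beyond the scatter). The expected change is a 6.0-fold higher number from compound 3 to compound 4 (0.78 log units; beyond the scatter). For compound 4 the estimated value is 12000 nM, with an expected range of 5000 nM to 30000 nM.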

Compound 4, half-maximal inhibitory concentration: 16600 nM
The estimate for compound 4 lay 1.4-fold (0.14 log units) below the measured number, and the stated range covers the measured number.
By their numbers in this assay, from the lowest: compound 3; then compound 1; then compound 4. At a limit, above all of these: compound 2.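

In this assay, cyclohexyl in place of isobutyl on a saturated chain carbon bound to a saturated ring carbon now has a step of measured size on the chloro-bearing pair, an 8.3-fold higher number from compound 3 to compound 4 (0.92 log units; beyond the scatter), where the methyl-bearing pair gave only a bound. The direction therefore holds on both cores shown, though the size of the step cannot be compared between them: the same change on two cores in this assay, an at least 4.5-fold higher number (0.65 log units; beyond the scatter) from compound 1 to compound 2 and an 8.3-fold higher number (0.92 log units; beyond the scatter) from compound 3 to compound 4; the limit leaves it open whether they differ The step for chloro in place of methyl on the cyclohexyl-bearing pair is an at least 1.8-fold lower number from compound 2 to compound 4 (0.25 log units; that floor lies within the scatter), a floor only, as the value of compound 2 is a limit of the assay, and whether this step matches the one on the isobutyl-bearing pair cannot be read.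

The compounds shown carry only isobutyl or cyclohexyl at this place, with chloro or methyl on the aromatic carbon, so how a phenyl ring, a longer chain or a chain ending in an amine would behave here remains open. Nothing shown tells why cyclohexyl gives the higher number on both cores.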